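Pyridin-2-yl in place of 4-methoxyphenyl: an expected limit

The source may report more compounds than this note shows. Statements on the series, on what has been measured and on what is new or still open speak of the compounds shown alone.

Compound 1, `COc1ccc(-c2cn(C[C@H]3c4c(ccc(O)c4C)[C@@H]4CC[C@@]5(C)C[C@]43CC5=O)nn2)cc1`, was run in a functional assay on SMMC-7721 cells (Homo sapiens) for cytotoxicity, read by MTT assay, with a stated time of 4 days; a higher number here means a weaker inhibitor, a lower number a stronger inhibitor. In this assay compound 1 gives > 20000 nM, which is a limit of the assay and not a number. Two further compounds were tested in the same way. Compound 2, `C=C1C[C@]23C[C@@]1(O)CC[C@H]2c1ccc(OS(=O)(=O)c2ccc(C)cc2)c(C)c1[C@@H]3Cn1cc(-c2ccc(C)cc2)nn1`, gives > 20000 nM in this assay, again a limit. Compound 3, `Cc1ccc(S(=O)(=O)Oc2ccc3c(c2C)[C@H](Cn2cc(-c4ccc(Br)cc4)nn2)[C@@]24CC(=O)[C@@](C)(CC[C@@H]32)C4)cc1`, gives > 20000 nM in this assay, also a limit. Going by the values given here, compound 1 therefore stands nowhere in particular among the three: the limit of > 20000 nM in this assay, at which 3 of the 3 values shown sit, so no ordering among them can be drawn from these readings, and no step between measured compounds is available.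

Compound 4, `Cc1c(O)ccc2c1[C@H](Cn1cc(-c3ccccn3)nn1)[C@@]13CC(=O)[C@@](C)(CC[C@@H]21)C3`, has not yet been measured in this assay. It differs from compound 1 in one place: pyridin-2-yl in place of 4-methoxyphenyl on an aromatic carbon. Among the compounds with values here, with no measured step to lean on, and with compound 2 and compound 3 showing only that a limit was reached, there is nothing to suggest that this change moves the reading out of the region where the three measured compounds sit.

The step that the limit leaves unreadable from compound 1 to compound 4 is expected to be none beyond the scatter. For compound 4 the estimate in this assay is 25000 nM, in the range 8000 nM to 80000 nM, with the expectation that the assay most likely reports a limit once more.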

Compound 4, half-maximal inhibitory concentration: > 20000 nM
Compound 4 gave a limit, no number; the forecaster's own chance of this, stated with the estimate: 75%; the middle value does not contradict the limit.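

In this assay compound 4 gives > 20000 nM, which is a limit of the assay and not a number. Compound 1 also stands at a limit, so no step can be read between compound 1 and compound 4. The compounds shown leave open whether any of their structural differences changes the reading, with all of them at one limit: the limit of > 20000 nM in this assay, at which 4 of the 4 values shown sit.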